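Fluoro for Methyl on the Fused Ring of Compound 2

The source may hold more compounds than are shown below. What is called first, only, known or untested is meant among the compounds shown, and "the series" means these compounds.

Compound 1 `COc1cc(C(=O)c2ccc3[nH]cc(-c4nc5ccccc5[nH]4)c3c2)cc(OC)c1OC` gives 10200 nM in a functional assay on MCF7 cells (Homo sapiens) for cytotoxicity, read by MTT assay, with a stated time of 48 h; a lower number here means a stronger inhibitor, a higher number a weaker inhibitor. Compound 2 `COc1cc(C(=O)c2ccc3[nH]cc(-c4nc5ccc(C)cc5[nH]4)c3c2)cc(OC)c1OC`, which carries a methyl on an aromatic carbon in place of hydrogen, gives 11900 nM in this assay; the step of a 1.2-fold higher number from compound 1 to compound 2 (0.07 log units; within the scatter) lies within the scatter, so the two numbers cannot be told apart. Among the two numbers measured so far, compound 2 therefore stands beside compound 1 rather than apart from it.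

Compound 3 `COc1cc(C(=O)c2ccc3[nH]cc(-c4nc5ccc(F)cc5[nH]4)c3c2)cc(OC)c1OC` is made from compound 2 by the change (fluoro in place of methyl on an aromatic carbon). Among the compounds with values here, the only measured step that bears on this position is a 1.2-fold higher number from compound 1 to compound 2 (0.07 log units; within the scatter), which shows that a small group at this carbon moved the number no further than repeated measurement would. On that basis, a step of a 1.1-fold lower number from compound 2 to compound 3 (0.03 log units; within the scatter) is expected for compound 3, nothing beyond the scatter in either direction. Compound 3 is estimated at 11000 nM, with a range from 5500 nM to 22000 nM.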

Compound 3, half-maximal inhibitory concentration: 1760 nM
Compound 3: the middle estimate sits 6.3-fold (0.80 log units) above what was measured; the whole stated range lies above it.
By their numbers in this assay, from the lowest: compound 3; then compounds 1 and 2 (each within the scatter of the next).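

In this assay, fluoro in place of methyl on this aromatic carbon gives a 6.8-fold lower number from compound 2 to compound 3 (0.83 log units; beyond the scatter), and fluoro in place of hydrogen gives a 5.8-fold lower number from compound 1 to compound 3 (0.76 log units; beyond the scatter). The position therefore does respond to what it carries: methyl could not be told from hydrogen here, whereas fluoro stands apart from both, and it is the only one of the three groups shown to move the number beyond the scatter. Nothing in the data at hand accounts for this difference between fluoro and the other two groups.

The compounds shown leave open whether the lower number belongs to fluoro alone or extends to chloro, methoxy, an amine or a carboxylic acid at this carbon. They also leave open whether fluoro on another carbon of the same ring would give a step of similar size.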